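The source may hold more compounds than are shown below. What is called first, only, known or untested is meant among the compounds shown, and "the series" means these compounds.

Compound 1, with structure `CCCCCCCCCCCO[C@@H]1[C@@H](N)[C@@H](O[C@H]2[C@H](O)[C@@H](OCCCCCCC)[C@H](N)C[C@@H]2N)O[C@H](CN)[C@H]1O`, carries two alkyl chains on its shared core. In an ADME assay on J774 cells (Mus musculus) for cytotoxicity, read by MTT assay, with a stated time of 24 h, tested at 30 uM (a lower number here means a stronger effect, a higher number a weaker effect of the compound at the concentration tested), compound 1 gives 39.1%, the lowest of the two numbers measured, and compound 2, with structure `CCCCCCCCCCCO[C@@H]1[C@@H](N)[C@@H](O[C@H]2[C@H](O)[C@@H](O)[C@H](N)C[C@@H]2N)O[C@H](CN)[C@H]1O`, gives 77.1%. Going by the values given here, the only measured step is a number 38 percentage points higher from compound 1 to compound 2 (beyond the scatter), in which hydrogen replaces heptyl on an oxygen on a saturated carbon. Compound 3, with structure `CCCCCCCO[C@@H]1[C@@H](O)[C@H](O[C@H]2O[C@H](CN)[C@@H](O)[C@H](O)[C@H]2N)[C@@H](N)C[C@H]1N`, has not yet been measured; it differs from compound 1 by hydrogen in place of undecyl on an oxygen on a saturated carbon. Since the removal of one chain in the step from compound 1 to compound 2 raised the number well beyond the scatter, removing the other chain is expected to act in the same direction, and a step of about a number 32.9 percentage points higher from compound 1 to compound 3 (beyond the scatter) is estimated. Compound 3 is therefore expected to give around 72%, within a range from 50% to 95%.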

Compound 3, a percentage reported as activity, at one concentration (the size of the read-out at that concentration, not a potency): 71.3%
The estimate for compound 3 lay 0.7 percentage points above the measured number; the range from low to high includes it.
By their numbers in this assay, from the lowest: compound 1; then compounds 3 and 2 (each within the scatter of the next).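

In this assay, exchanging the undecyloxy group for hydroxy gives a number 32.2 percentage points higher from compound 1 to compound 3 (beyond the scatter). This shows that the undecyl chain counts at its own position, whereas the earlier pair showed only the loss of the heptyl chain, with a number 38 percentage points higher from compound 1 to compound 2 (beyond the scatter). Compound 1, the only one here with both chains, has the lowest number, and removing either chain raises it, with no compound shown going against this; nothing available explains why the number changes.

The compounds shown leave open how a shorter chain such as butyl, or an amine in place of the hydroxy, would read at this position. They also leave open how the shared core would read with a hydroxy in place of both chains.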